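This account rests on a few compounds, and the source may have more. Where it says the series, first, only, none or still open, it means among the compounds named here.

Working notes on the series. Going by the values given here, in a functional assay on HT-29 cells (Homo sapiens) for cytotoxicity, read by sulforhodamine B assay, with a stated time of 2 days, tested at 100 uM (a lower number here means less inhibition, a higher number more inhibition at the concentration tested (going by the name of the read-out)), compound 2 `O=C(Nn1c(-c2cccc([N+](=O)[O-])c2)nc2c(-c3cccc(Cl)c3)n[nH]c2c1=O)c1ccccc1` gives 89.8%, the highest of the two numbers so far; compound 1 `O=C(Nn1c(-c2cccc([N+](=O)[O-])c2)nc2c(-c3ccc(F)cc3)n[nH]c2c1=O)c1cccnc1` gives 24.7% in this assay, a gap beyond the scatter. Among the compounds with values here, compound 1 and compound 2 differ in two places, so no single step between them can be read from these two values.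

Compound 3 `O=C(Nn1c(-c2cccc([N+](=O)[O-])c2)nc2c(-c3ccc(F)cc3)n[nH]c2c1=O)c1ccccc1` has not been measured in this assay. It differs from compound 2 by one change: 4-fluorophenyl in place of 3-chlorophenyl on an aromatic carbon. Within the data shown here, no measured pair isolates this change, so its size and direction are unknown; compound 1 also carries the 4-fluorophenyl group and gives 24.7% in this assay, but its other difference from compound 2 clouds the reading. A downward step from compound 2 of a number 34.8 percentage points lower from compound 2 to compound 3 (beyond the scatter) is expected, of uncertain size. Compound 3 is estimated at 55% in this assay, within 20% to 90%.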

Compound 3, a percentage reported as inhibition, at one concentration (the size of the read-out at that concentration, not a potency): 92%
The estimate for compound 3 lay 37 percentage points below the measured number; measured number above the stated range.
By their numbers in this assay, from the lowest: compound 1; then compounds 2 and 3 (each within the scatter of the next).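

In this assay, 4-fluorophenyl in place of 3-chlorophenyl on an aromatic carbon of the five-membered ring gives a number 2.2 percentage points higher from compound 2 to compound 3 (within the scatter), so these two aryl groups cannot be told apart at this position at the one concentration tested. Going by these compounds alone, the wide gap seen earlier can now be assigned to the other place: phenyl in place of pyridin-3-yl on a carbonyl carbon gives a number 67.3 percentage points higher from compound 1 to compound 3 (beyond the scatter), the only single change so far that lies beyond the scatter. No measurement shown gives a cause for either step.

On these data alone, whether pyridin-3-yl has the same size of step alongside 3-chlorophenyl remains open. Also open, as far as these compounds go, is whether a carboxylic acid or an amine on the phenyl ring at the aromatic carbon, or a cyclohexyl group in its place, would stay within the scatter of compound 3.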